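The source may report more compounds than this note shows. Statements on the series, on what has been measured and on what is new or still open speak of the compounds shown alone.

Working notes on the series. Compound 1 `COc1ccccc1/C=C/C(=O)c1cc(NC(C)=O)ccc1O` and compound 2 `CC(=O)Nc1ccc(O)c(C(=O)/C=C/c2ccccc2F)c1` share one core; compound 3 `COc1ccccc1-c1cc(=O)c2cc(N)ccc2o1` and compound 4 `Nc1ccc2oc(-c3ccccc3F)cc(=O)c2c1` share another, and the difference between the two cores is not broken down here.

In an ADME assay on MT4 cells (Homo sapiens) for cytotoxicity, read by MTT assay, with a stated time of 4 days (on this read-out lower numbers stand for higher toxicity in this test and higher numbers for lower toxicity in this test), compound 1 gives 37800 nM and compound 2 gives 33800 nM. The change that separates them is fluoro in place of methoxy on an aromatic carbon, and it brings a 1.1-fold lower number from compound 1 to compound 2 (0.05 log units; within the scatter). In this assay compound 3 gives 198000 nM, the highest of the three numbers; the gap to compound 1, its nearest neighbour, is beyond the scatter, as is the gap to compound 2.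

Compound 4 is not yet measured. It differs from compound 3 by fluoro in place of methoxy on an aromatic carbon, the same change as between compound 1 and compound 2, at a place described in the same words. Going by the values given here, the one measured instance of this change stayed within the scatter, so the number for compound 4 is expected to lie near that of compound 3. The expected step is a 1.1-fold lower number from compound 3 to compound 4 (0.04 log units; within the scatter), resting on the earlier step of a 1.1-fold lower number from compound 1 to compound 2 (0.05 log units; within the scatter). For compound 4 in this assay the estimate is 180000 nM, with a range from 90000 nM to 360000 nM.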

Compound 4, half-maximal cytotoxic concentration: 283000 nM
Estimate against measurement, compound 4: 1.6-fold (0.20 log units) below; low and high end bracket the measured number.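

In this assay, fluoro in place of methoxy on an aromatic carbon gives a 1.4-fold higher number from compound 3 to compound 4 (0.16 log units; within the scatter), and the two instances of this change can be set side by side: the same change on two cores in this assay, a 1.1-fold lower number (0.05 log units; within the scatter) from compound 1 to compound 2 and a 1.4-fold higher number (0.16 log units; within the scatter) from compound 3 to compound 4, 1.6-fold (0.20 log units) apart, within the scatter of two such steps. On the two cores shown, the change therefore carries over in the limited sense that neither step leaves the scatter and the steps cannot be told apart. This does not show that the steps are identical, since steps this small could hide a modest dependence on the core, and two cores and one assay say nothing about how the change would behave on a further core or in another read-out.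

Still open, from the compounds shown here alone, is whether other groups at the same place, such as chloro, trifluoromethyl or a longer ether chain like ethoxy, would also stay within the scatter. The compounds shown also leave open what separates the two cores, as no step between them is available here.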